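A few compounds are considered here, and "the series" means these few. Any claim that something is new, unique, unknown or untested is made for them only; others in the source may bear on it.

Measured so far:
- compound 1 `Cn1c(=O)c(S(=O)(=O)Cc2ccc(F)cc2)cc2cnc(Nc3ccc4[nH]ccc4c3)nc21`: 30000 nM
- compound 2 `COc1ccc(S(=O)(=O)c2cc3cnc(Nc4ccc5[nH]ccc5c4)nc3n(C)c2=O)cc1`: 300 nM
- compound 3 `Cn1c(=O)c(S(=O)(=O)Nc2ccc(F)cc2)cc2cnc(Nc3ccc4[nH]ccc4c3)nc21`: 5000 nM

In a functional assay on K562 cells (Homo sapiens) for inhibition, read by trypan blue exclusion, with a stated time of 72 h (a lower number here means a stronger inhibitor, a higher number a weaker inhibitor), compound 3 gives 5000 nM, the second highest of the three numbers. Two steps place it: a 6.0-fold lower number from compound 1 to compound 3 (0.78 log units; beyond the scatter), and a 17-fold higher number from compound 2 to compound 3 (1.22 log units; beyond the scatter).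

Compound 4 `Cn1c(=O)c(S(=O)(=O)Nc2ccc(F)cc2F)cc2cnc(Nc3ccc4[nH]ccc4c3)nc21` has fluoro in place of hydrogen on an aromatic carbon, ortho to a large group and meta to a fluoro group: fluoro in place of hydrogen on an aromatic carbon.

Among the compounds with values here, no measured step isolates this change. The nearest evidence is a 6.0-fold lower number from compound 1 to compound 3 (0.78 log units; beyond the scatter), with a 17-fold higher number from compound 2 to compound 3 (1.22 log units; beyond the scatter) and a 100-fold lower number from compound 1 to compound 2 (2.00 log units; beyond the scatter) alongside it, and each of these exchanges the whole group on the sulfonyl sulfur. Those large steps therefore set no size for a fluoro in place of hydrogen, and the smaller change leads to an expectation of little movement in this assay.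

Within the data shown here, the expected result is a 1.3-fold lower number from compound 3 to compound 4 (0.10 log units; within the scatter), with no step expected beyond the scatter.

For compound 4 the estimated value is 4000 nM, with an expected range of 1500 nM to 12000 nM.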

Compound 4, half-maximal inhibitory concentration: 5000 nM
Beside the measured number, compound 4's estimate is 1.3-fold (0.10 log units) below it, within the range that was stated.
By their numbers in this assay, from the lowest: compound 2; then compounds 3 and 4 (each within the scatter of the next); then compound 1.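

In this assay the first fluoro added to this ring, ortho to a large group and meta to a fluoro group, gives no change at the digits printed from compound 3 to compound 4 (within the scatter) and so does not separate the two compounds. The exchange on the sulfonyl sulfur remains the larger change here, with a 17-fold higher number from compound 2 to compound 4 (1.22 log units; beyond the scatter) and a 6.0-fold lower number from compound 1 to compound 4 (0.78 log units; beyond the scatter) matching in size the steps printed for the (4-fluorophenyl)amino compound, so (2,4-difluorophenyl)amino sits in the same place in the series as (4-fluorophenyl)amino. No measured evidence bears on why this position shows no step.

The compounds shown leave open whether this position would stay as flat with a group other than fluoro, such as chloro, methyl or a carboxylic acid. They also leave open whether the same fluoro on the 4-methoxyphenyl group of compound 2 would read the same way.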